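The source may report more compounds than this note shows. Statements on the series, on what has been measured and on what is new or still open speak of the compounds shown alone.

Compound 1 `COc1cccc(NC(=O)Nc2ccc(Nc3ncnc4c3OCCN4)cc2)c1`: > 10000 nM, a limit.
Compound 2 `Cc1ccc(F)c(NC(=O)Nc2ccc(Nc3ncnc4c3OCCN4)cc2)c1`: > 10000 nM, a limit.

These results come from a functional assay on BaF3 cells (Mus musculus) for inhibition, read by MTT assay, with a stated time of 3 days; a higher number here means a weaker inhibitor of growth, a lower number a stronger inhibitor of growth. Neither compound gives a number, and the evidence so far is the limit of > 10000 nM in this assay, at which 2 of the 2 values shown sit. Compound 2 therefore stands at a limit of the assay, not at a measured potency.

Compound 3 `O=C(Nc1ccc(Nc2ncnc3c2OCCN3)cc1)Nc1cc(Cl)cc(Cl)c1` carries 3,5-dichlorophenyl in place of 2-fluoro-5-methylphenyl on an amide-type nitrogen. Among the compounds with values here, the only measured step bearing on this change is a step that the two limits leave unreadable from compound 1 to compound 2. That step changes the group at the same place, but it provides no size and no direction to carry forward. In this assay, no clear shift is therefore expected, and another limit is the likeliest result. The expected change is a number no higher from compound 2 to compound 3 (the limit leaves the size open). For compound 3, the estimated value is 10000 nM, with an expected range of 3000 nM to 30000 nM.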

Compound 3, concentration for 50% growth inhibition: 10000 nM
Compound 3: the middle estimate sits on the measured number at the digits printed, within the range that was stated.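

In this assay compound 3 gives 10000 nM, so with 3,5-dichlorophenyl on this amide-type nitrogen the compounds shown reach a measured number for the first time, and the data show a number no higher from compound 2 to compound 3 (the limit leaves the size open) and a number no higher from compound 1 to compound 3 (the limit leaves the size open). The steps to it from compound 1 and from compound 2 cannot be read, so neither the size of the change nor any real gain in strength can be stated. Compound 1 and compound 2 remain limits rather than numbers: the limit of > 10000 nM in this assay, at which 2 of the 3 values shown sit.

From the compounds shown here alone, it remains open whether a phenyl ring carrying a trifluoromethyl group or a single chlorine on this nitrogen would bring the number clearly lower. Going by these compounds, it is also open whether a value this close to the limit marks a true difference between compound 3 and the two earlier compounds.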